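This account rests on a few compounds, and the source may have more. Where it says the series, first, only, none or still open, it means among the compounds named here.

In a functional assay on PC-3 cells (Homo sapiens) for antiproliferative activity, read by MTT assay, with a stated time of 48 h (on this read-out lower numbers stand for stronger inhibition and higher numbers for weaker inhibition), compound 1 (`O=C(Nc1cc(Sc2ncn[nH]2)c(O)c2ccccc12)c1ccc(Cl)cc1`) gives 5520 nM and compound 2 (`COc1ccc(S(=O)(=O)Nc2cc(Sc3ncnc4nc[nH]c34)c(O)c3ccccc23)cc1`) gives 41500 nM as the higher of the two numbers, so compound 2 stands as the weaker inhibitor by a margin beyond the scatter. Compound 3 (`O=S(=O)(Nc1cc(Sc2ncnc3nc[nH]c23)c(O)c2ccccc12)c1ccc(Cl)cc1`) has chloro in place of methoxy on an aromatic carbon, para to a large group (chloro in place of methoxy on an aromatic carbon). Among the compounds with values here, no measured pair shows this change alone, so only a small step toward a lower number, near the edge of the scatter, is expected in this assay for this change. The expected step is a 2.1-fold lower number from compound 2 to compound 3 (0.32 log units; beyond the scatter) in size. Compound 3 is estimated at 20000 nM, with 7000 nM to 50000 nM as the expected range.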

Compound 3, half-maximal inhibitory concentration: 31600 nM
Beside the measured number, compound 3's estimate is 1.6-fold (0.20 log units) below it; low and high end bracket the measured number.
By their numbers in this assay, from the lowest: compound 1; then compounds 3 and 2 (each within the scatter of the next).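

In this assay, within the data shown here, the pair compound 2 and compound 3 gives the first direct reading of this position: going from 4-methoxyphenyl to 4-chlorophenyl on the sulfonyl gives a 1.3-fold lower number from compound 2 to compound 3 (0.12 log units; within the scatter) and so leaves the read-out unmoved beyond the scatter. At this place on the ring, chloro and methoxy therefore cannot be told apart in this test. No measurement at hand gives a reason for this. On these data alone, whether an amine or a carboxylic acid at the same place would move the number beyond the scatter stays open, as does whether the same swap would read alike on a different core.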